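A few compounds are considered here, and "the series" means these few. Any claim that something is new, unique, unknown or untested is made for them only; others in the source may bear on it.

The series rests on the core of compound 1 `CCOC(=O)C(C)C(O)(c1ccc(OC)c(OC)c1OC)c1cccc2ccccc12`. In a functional assay on MCF7 cells (Homo sapiens) for inhibition, read by sulforhodamine B assay, with a stated time of 48 h (a higher number here means a weaker inhibitor, a lower number a stronger inhibitor), compound 1 gives > 20000 nM, which is a limit of the assay rather than a measured number (the limit of > 20000 nM in this assay, at which 1 of the 2 values shown sits). A second member, compound 2 `COc1ccc(C(c2ccccc2O)c2cccc3ccccc23)c(OC)c1OC`, differs from compound 1 in more than one place; in this assay compound 2 gives 16600 nM. For the measured compounds named here, no pair in this set differs in one place alone, so no measured step is available to lean on. The unmeasured compound 3 `COc1ccc(C(O)(Cc2ccc(F)cc2)c2cccc3ccccc23)c(OC)c1OC` differs from compound 1 in one place: 4-fluorobenzyl in place of 1-(ethoxycarbonyl)ethyl on a saturated chain carbon bound to two aromatic carbons and an oxygen on a saturated carbon. Going by the values given here, with only a limit for compound 1 and no measured step for guidance, the step of an at least 1.6-fold lower number from compound 1 to compound 3 (0.22 log units; that floor lies within the scatter) is expected to be modest, if anything toward stronger inhibition, and possibly not beyond the usual scatter. Compound 3 is therefore estimated at 12000 nM, within 4000 nM to 30000 nM.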

Compound 3, half-maximal inhibitory concentration: 7560 nM
The estimate for compound 3 lay 1.6-fold (0.20 log units) above the measured number, and the stated range covers the measured number.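

On a saturated chain carbon bound to two aromatic carbons and an oxygen on a saturated carbon, 4-fluorobenzyl in place of 1-(ethoxycarbonyl)ethyl gives, in this assay, an at least 2.6-fold lower number from compound 1 to compound 3 (0.42 log units; beyond the scatter). For the compounds shown here, this is the first change in one place that can be read, and it shows that this position tolerates an aromatic group and that the ester-bearing chain is not required for a measurable number. Compound 1 stands at a limit and not at a measured number, so the step gives only a floor and its full size stays unknown: the limit of > 20000 nM in this assay, at which 1 of the 3 values shown sits.

The compounds shown leave open whether the lower number follows the fluorine, the aromatic ring or the loss of the ester, all of which come together in this single change. An unsubstituted benzyl, a longer alkyl chain or an amine at this position would be needed to separate these parts.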